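A few compounds are considered here, and "the series" means these few. Any claim that something is new, unique, unknown or untested is made for them only; others in the source may bear on it.

Compound 1 `COc1ccc(Br)cc1Nc1cc(NC(=O)Nc2c(Cl)cccc2Cl)ncn1` gives 33% in a functional assay on NCI-H226 cells (Homo sapiens) for inhibition, read by MTT assay, with a stated time of 48 h, tested at 10 uM; on this read-out lower numbers stand for less inhibition and higher numbers for more inhibition at the one concentration tested (going by the name of the read-out).
Compound 2 `COc1cc(NC(=O)Nc2cc(Nc3cc(Br)ccc3OC)ncn2)cc(OC)c1` gives 42.7% in this assay.
Compound 3 `CCc1ccc(Nc2cc(NC(=O)Nc3c(Cl)cccc3Cl)ncn2)cc1` gives 39.5% in this assay.

Compound 1 holds the lowest of the three numbers, yet both of the others lie within the usual scatter of it, so the three cannot be ranked. The step from compound 1 to compound 4 `COc1ccc(OC)c(Nc2cc(NC(=O)Nc3c(Cl)cccc3Cl)ncn2)c1` is a small change: methoxy in place of bromo on an aromatic carbon. Two measured steps give some guidance. The step of a number 6.5 percentage points higher from compound 1 to compound 3 (within the scatter) alters the same part of the molecule, the group on the nitrogen on an aromatic ring, but replaces it entirely rather than swapping one substituent. The step of a number 9.7 percentage points higher from compound 1 to compound 2 (within the scatter) alters the other end, on the amide-type nitrogen. Neither step moved the number beyond the scatter, and neither is the exact swap in question, so the expectation for compound 4 is a step of about a number 3 percentage points higher from compound 1 to compound 4 (within the scatter) in this assay, that is, no change beyond the scatter. Compound 4 is therefore estimated at 36%, within a range from 20% to 52%.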

Compound 4, a percentage reported as inhibition, at one concentration (the size of the read-out at that concentration, not a potency): 81.7%
Beside the measured number, compound 4's estimate is 45.7 percentage points below it; the measured number lies above the stated range.
By their numbers in this assay, from the lowest: compounds 1, 3 and 2 (each within the scatter of the next); then compound 4.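

The carbon para to a methoxy group turns out to be a sensitive position: methoxy in place of bromo there gives a number 48.7 percentage points higher from compound 1 to compound 4 (beyond the scatter) in this assay. The earlier steps shown here gave no sign of this, as even replacing the whole group on that nitrogen gave only a number 6.5 percentage points higher from compound 1 to compound 3 (within the scatter), so exchanging one substituent here counts for far more than that larger replacement did. No measurement among these compounds explains the jump.

On these data alone, whether the gain belongs to methoxy in particular or simply to the loss of bromo remains open, and an ethoxy, a hydroxyl or an amine on this same carbon would help separate the two. Also open, as far as these compounds go, is whether the 3,5-dimethoxyphenyl group of compound 2, in place of 2,6-dichlorophenyl, would keep the high number of compound 4.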